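Swapping Cyclohexyl for Pyridin-2-yl on the Aorta Assay

This account rests on a few compounds, and the source may have more. Where it says the series, first, only, none or still open, it means among the compounds named here.

Measured so far:
- compound 1, `COc1cc(C(C)=O)ccc1OCCCN1CCC(C(c2ccc(F)cc2)c2ccc(F)c(F)c2)CC1`: 1.26 nM
- compound 2, `COc1cc(C(C)=O)ccc1OCCCN1CCC(C(c2ccc(F)cc2)C2CCCCC2)CC1`: 5.01 nM

Compound 1 and compound 2 share a core and differ only in the group on a saturated chain carbon bound to an aromatic carbon and a saturated ring carbon. In a functional assay (aorta) with Oryctolagus cuniculus as the target (a lower number here means tighter binding, a higher number weaker binding), compound 1 gives 1.26 nM, while compound 2 gives 5.01 nM. Among the compounds with values here, of the two numbers, compound 2 stands highest, the step of a 4.0-fold higher number from compound 1 to compound 2 (0.60 log units; beyond the scatter) being the only measured step in this set.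

Compound 3, `COc1cc(C(C)=O)ccc1OCCCN1CCC(C(c2ccc(F)cc2)c2ccccn2)CC1`, has not yet been measured. It differs from compound 2 in one place: pyridin-2-yl in place of cyclohexyl on a saturated chain carbon bound to an aromatic carbon and a saturated ring carbon. Within the data shown here, the one step that bears on this change is the one from compound 1 to compound 2, where a six-membered non-aromatic ring replaced an aromatic ring and the number rose by a 4.0-fold higher number from compound 1 to compound 2 (0.60 log units; beyond the scatter). Compound 3 moves back to an aromatic six-membered ring, so the expectation is that the number falls again, with the step of a 2.5-fold lower number from compound 2 to compound 3 (0.40 log units; beyond the scatter) expected to be modest. Compound 3 is therefore estimated at 2 nM, within a range from 0.8 nM to 6 nM.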

Compound 3, dissociation constant: 158 nM
Estimate against measurement, compound 3: 79-fold (1.90 log units) below, and the stated range ends below it.
By their numbers in this assay, from the lowest: compound 1; then compound 2; then compound 3.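

In this assay, being an aromatic six-membered ring is clearly not enough to give a low number at this position: pyridin-2-yl in place of cyclohexyl gives a large rise (a 32-fold higher number from compound 2 to compound 3 (1.50 log units; beyond the scatter)) rather than a fall. Pyridin-2-yl in place of 3,4-difluorophenyl, one aromatic ring for another, gives a larger rise still (a 130-fold higher number from compound 1 to compound 3 (2.10 log units; beyond the scatter)), so the two aromatic groups stand at opposite ends of the three numbers, with cyclohexyl in the middle, and compound 3 goes against any rule that aromatic rings here give the lowest numbers. What the ring carries therefore matters a great deal at this place, but nothing available explains the size of these steps.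

Pyridin-2-yl differs from 3,4-difluorophenyl both in having a ring nitrogen and in lacking the two fluorines, and these compounds do not separate the two changes. Unsubstituted phenyl at this place would help to separate them, and pyridin-3-yl would show whether the higher number follows the ring nitrogen wherever it stands in the ring.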